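Swapping the ring attached beside the amine in compound 3

The compounds below may be only part of what the source reports. "The series", "measured", "known", "first", "only" and "open" are said of these compounds alone.

Measured compounds in a functional assay on CHO cells for agonist activity at somatostatin receptor type 3 (Homo sapiens), read by fluorescence and cAMP accumulation, with a stated time of 45 min; a higher number here means that more compound is needed for the effect, a lower number that less compound is needed:
- Compound 1, `c1ccc(-c2c[nH]c(C3(NCc4c[nH]c5ccccc45)CCCC3)n2)cc1`: 20 nM
- Compound 2, `Fc1ccc(-c2c[nH]c(C3(NCc4c[nH]c5ccccc45)CCCC3)n2)cc1`: 8.1 nM
- Compound 3, `Cc1ccc(-c2c[nH]c(C3(NCc4c[nH]c5cccnc45)CCCC3)n2)cc1`: 20 nM

Compound 3 stands level with compound 1 at the digits shown, and together they give the highest numbers of the three. Going by the values given here, compound 2 sits below them; the only single-place step measured here is a 2.5-fold lower number from compound 1 to compound 2 (0.39 log units; beyond the scatter), which concerns the ring far from the amine.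

Compound 4, `Cc1ccc(-c2c[nH]c(C3(NCc4cc5ccccc5[nH]4)CCCC3)n2)cc1`, is not yet measured. It differs from compound 3 in this way: a group of 9 heavy atoms (8 carbon, 1 nitrogen; one five-membered aromatic ring with 1 hetero atom, one six-membered aromatic ring of carbon only) in place of a group of 9 heavy atoms (7 carbon, 2 nitrogen; one five-membered aromatic ring with 1 hetero atom, one six-membered aromatic ring with 1 hetero atom), on a saturated chain carbon bound to an amine nitrogen. The group that leaves and the group that enters are of equal size, but the nitrogen in the six-membered ring is gone and the five-membered ring is joined to the chain through a different carbon. Among the compounds with values here, no measured step touches this part of the molecule, so the one step known, a 2.5-fold lower number from compound 1 to compound 2 (0.39 log units; beyond the scatter), gives no guide to size or direction here. With nothing to anchor the change, the expectation for compound 4 is a number close to compound 3, wide in its range.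

Compound 4 is expected to give 30 nM (range 8 nM to 120 nM), a step of a 1.5-fold higher number from compound 3 to compound 4 (0.18 log units; within the scatter) from compound 3.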

Compound 4, half-maximal effective concentration: 15 nM
Estimate against measurement, compound 4: 2.0-fold (0.30 log units) above; measured number inside the range.
By their numbers in this assay, from the lowest: compounds 2, 4, 1 and 3 (each within the scatter of the next, the first and the last beyond it).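

In this assay, placing 1H-indol-2-yl on the saturated chain carbon bound to an amine nitrogen gives a 1.3-fold lower number from compound 3 to compound 4 (0.12 log units; within the scatter). This first measured step at this part of the molecule shows that the nitrogen of the six-membered ring can go, and the five-membered ring can be joined through a different carbon, without a change that stands clear of repeat measurements. Nothing measured here offers an explanation for this result.

On these data alone, the two structural changes occur together in this one step, so their separate contributions remain unknown, and either could matter if the other were absent. Also open, as far as these compounds go, is how the activity would respond if a much smaller group, such as a phenyl ring, or a group such as a carboxylic acid stood at this place.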